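This account rests on a few compounds, and the source may have more. Where it says the series, first, only, none or still open, it means among the compounds named here.

Measured so far:
compound 1, `O=C1Nc2cc(Cl)c(F)cc2/C1=N/NC(=S)Nc1ccc(Cl)cc1`, 43000 nM
compound 2, `Cc1ccc(NC(=S)N/N=C2\C(=O)Nc3cc(Cl)c(F)cc32)cc1`, 112000 nM
compound 3, `Cc1ccc(NC(=S)N/N=C2\C(=O)N(Cc3ccc(Cl)cc3)c3ccc(Br)cc32)cc1`, 288000 nM

All three numbers come from a functional assay on MOLT-4 cells (Homo sapiens), with a stated time of 72 h; a lower number here means a stronger inhibitor, a higher number a weaker inhibitor. Going by the values given here, the one single-point step among them is methyl in place of chloro on an aromatic carbon, which gives a 2.6-fold higher number from compound 1 to compound 2 (0.42 log units; beyond the scatter). Compound 3 stands highest of the three, and the difference between its core and that of compound 1 is not broken down here; the two numbers simply show compound 3 well beyond both.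

Compound 4, `Cc1ccc(CN2C(=O)/C(=N\NC(=S)Nc3ccc(C)cc3)c3cc(Br)ccc32)cc1`, is not yet measured. It is obtained from compound 3 by methyl in place of chloro on an aromatic carbon. The place of the change reads the same as for compound 1 to compound 2, though cut one bond further out it reads 4-chlorobenzyl to 4-methylbenzyl rather than (4-chlorophenyl)amino to (4-methylphenyl)amino, so it is the same kind of change set on a different part of the molecule. Among the compounds with values here, with only that one earlier step to rest on, the step from compound 3 to compound 4 is expected to be a 2.4-fold higher number from compound 3 to compound 4 (0.39 log units; beyond the scatter), similar in size to a 2.6-fold higher number from compound 1 to compound 2 (0.42 log units; beyond the scatter). Compound 4 is therefore estimated at 700000 nM, within 250000 nM to 2000000 nM.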

Compound 4, half-maximal inhibitory concentration: 393000 nM
Beside the measured number, compound 4's estimate is 1.8-fold (0.25 log units) above it; low and high end bracket the measured number.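

In this assay, methyl in place of chloro on an aromatic carbon gives a 1.4-fold higher number from compound 3 to compound 4 (0.14 log units; within the scatter), so on this core the change leaves no effect that can be told from scatter. Set beside the earlier step on the other core, the two results cannot be told apart: the same change on two cores in this assay, a 2.6-fold higher number (0.42 log units; beyond the scatter) from compound 1 to compound 2 and a 1.4-fold higher number (0.14 log units; within the scatter) from compound 3 to compound 4, 1.9-fold (0.28 log units) apart, within the scatter of two such steps. This shows no detectable dependence of the step on the core across these two pairs, but it does not show that the step has one fixed size in the series, and the change sits on a 4-chlorophenyl group in one pair and on a 4-chlorobenzyl group in the other, so core and site are not separated.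

Still open, on these data alone, is how the same change behaves at the 4-chlorophenyl site on the core of compound 3, which would separate site from core. Only chloro and methyl are shown at this place, leaving groups such as methoxy, an amine or a carboxylic acid open.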